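From 1,3-thiazol-5-yl to (cyclopent-1-en-1-yl)methyl: compound 4

The source may hold more compounds than are shown below. What is called first, only, known or untested is meant among the compounds shown, and "the series" means these compounds.

Measured in an ADME assay on Huh-7 cells (Homo sapiens) for cytotoxicity, with a stated time of 72 h; a lower number here means that less compound is tolerated, a higher number that more compound is tolerated:
- compound 1 `CC(C)CCn1nc(-c2cccs2)c(O)c(C2=NS(=O)(=O)c3cc(NS(=O)(=O)C4CC4)ccc3N2)c1=O`: > 1000 nM
- compound 2 `CC(C)CCn1nc(-c2cccs2)c(O)c(C2=NS(=O)(=O)c3cc(N(C(C)C)S(C)(=O)=O)ccc3N2)c1=O`: "not determined" (no result reported)
- compound 3 `CC(C)CCn1nc(-c2cncs2)c(O)c(C2=NS(=O)(=O)c3cc(NS(C)(=O)=O)ccc3N2)c1=O`: > 33000 nM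

In this assay compound 3 gives > 33000 nM, which is a limit and not a number. Compound 1 gives > 1000 nM, which is also a limit. Compound 2 has no reported result: "not determined" (no result reported). Going by the values given here, no compound in this set therefore has a single number, and no order can be drawn among them.

Compound 4 `CC(C)CCn1nc(CC2=CCCC2)c(O)c(C2=NS(=O)(=O)c3cc(NS(C)(=O)=O)ccc3N2)c1=O` has not yet been measured. It differs from compound 3 in one place: (cyclopent-1-en-1-yl)methyl in place of 1,3-thiazol-5-yl on an aromatic carbon. The (cyclopent-1-en-1-yl)methyl group stands in place of 1,3-thiazol-5-yl on an aromatic carbon, ortho to a hydroxy group.

Among the compounds with values here, no measured pair isolates this change, so the expectation has little support. It starts from compound 3 at > 33000 nM, a limit. A small move toward less compound tolerated is expected, and the estimated change is an at least 1.6-fold lower number from compound 3 to compound 4 (0.21 log units; that floor lies within the scatter). Another report as a limit is also expected to be quite possible. For compound 4 the estimated half-maximal cytotoxic concentration is 20000 nM, with an expected range of 6000 nM to 50000 nM.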

Compound 4, half-maximal cytotoxic concentration: > 33000 nM
Compound 4 gave a limit, no number; the forecaster's own chance of this, stated with the estimate: 60%; at least 1.6-fold (0.21 log units) between middle value and limit.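

In this assay compound 3 and compound 4 both stop at the same limit, so no step can be read between them: the limit of > 33000 nM in this assay, at which 2 of the 4 values shown sit.

The compounds shown leave open whether (cyclopent-1-en-1-yl)methyl in place of 1,3-thiazol-5-yl changes the half-maximal cytotoxic concentration at all, and what single number either compound would give.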